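Chloro for methyl on the pyridinyl ring of a urea

The compounds below may be only part of what the source reports. "The series", "measured", "known", "first", "only" and "open" are said of these compounds alone.

Measured compounds:
compound 1 `CC(C)N(CCN(C(=O)N(C)C)c1ccccn1)C(C)C` with 17%
compound 2 `Cc1cccc(N(CCN(C(C)C)C(C)C)C(=O)N(C)C)n1` with 87%

For the measured compounds named here, in a functional assay on the whole organism (stomach) for inhibition, with Canis familiaris (Canis lupus familiaris) as the target, at a dose of 20 mg/kg by the oral route (a higher number here means a stronger effect of the compound at the dose given, a lower number a weaker effect), compound 2 gives the higher of the two numbers; its nearest neighbour is compound 1, and the single measured step is a number 70 percentage points higher from compound 1 to compound 2 (beyond the scatter). Compound 3 `CC(C)N(CCN(C(=O)N(C)C)c1ccc(Cl)cn1)C(C)C` has not been measured. It differs from compound 2 by 5-chloropyridin-2-yl in place of 6-methylpyridin-2-yl on an amide-type nitrogen. Going by the values given here, no measured step shows this change; the only step known, from compound 1 to compound 2, concerns a methyl on an aromatic carbon, and it was large. That step shows the ring substituent matters, but it gives no direct guide to a chloro at another position. Compound 3 is therefore expected to fall between compounds 1 and 2, as a step of a number 42 percentage points lower from compound 2 to compound 3 (beyond the scatter). The estimate for compound 3 in this assay is 45%, with a range from 15% to 80%.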

Compound 3, a percentage reported as inhibition, in the whole organism at one dose (the size of the read-out at that dose, not a potency): 63%
The estimate for compound 3 lay 18 percentage points below the measured number; the range from low to high includes it.
By their numbers in this assay, from the lowest: compound 1; then compound 3; then compound 2.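

In this assay, the step of a number 46 percentage points higher from compound 1 to compound 3 (beyond the scatter) shows that the gain over the unsubstituted pyridin-2-yl of compound 1 is not confined to a methyl: a chloro group also brings a large rise. The exchange of 6-methylpyridin-2-yl for 5-chloropyridin-2-yl on the amide-type nitrogen gives a number 24 percentage points lower from compound 2 to compound 3 (beyond the scatter), so this chloro group keeps much of that gain but does not match the methyl group, and because the substituent's kind and ring position change together, this one step cannot separate them. Nothing available accounts for either step.

The compounds shown leave open how 6-chloropyridin-2-yl and 5-methylpyridin-2-yl would compare, which would separate the two changes. They also leave open whether a methoxy or an amine on the ring would give a similar rise.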